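The source may hold more compounds than are shown below. What is called first, only, known or untested is meant among the compounds shown, and "the series" means these compounds.

Compound 1 `COc1cc(-c2cc(/C=C/C(=O)c3ccc(N)cc3)[nH]n2)cc(OC)c1OC` and compound 2 `COc1ccc(-c2cc(/C=C/C(=O)c3ccc(N)cc3)[nH]n2)cc1OC` share one core, and the change hydrogen in place of methoxy on an aromatic carbon turns the first into the second. In a functional assay on HOP-92 cells (Homo sapiens) for cytotoxicity, read by sulforhodamine B assay, with a stated time of 48 h, tested at 1 uM (a higher number here means a weaker effect of the compound at the concentration tested, a lower number a stronger effect), compound 1 gives 79%, while compound 2 gives 87%, a step of a number 8 percentage points higher from compound 1 to compound 2 (within the scatter). Compound 3 `COc1cc(C(=O)/C=C/c2cc(-c3cc(OC)c(OC)c(OC)c3)n[nH]2)cc(OC)c1OC` is built on a different core; how the two cores differ is not broken down here. In this assay compound 3 gives 1%, the lowest of the three numbers, with compound 1 and compound 2 both beyond the scatter above it. Compound 4 `COc1ccc(-c2cc(/C=C/C(=O)c3cc(OC)c(OC)c(OC)c3)[nH]n2)cc1OC` arises from compound 3 by hydrogen in place of methoxy on an aromatic carbon, the same change made from compound 1 to compound 2, at a place described in identical words. Because that earlier step was a number 8 percentage points higher from compound 1 to compound 2 (within the scatter), compound 4 is expected to move by only about a number 9 percentage points higher from compound 3 to compound 4 (within the scatter). The estimate for compound 4 in this assay is 10%, expected to fall between 0% and 45%.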

Compound 4, a percentage reported as activity, at one concentration (the size of the read-out at that concentration, not a potency): 70%
Beside the measured number, compound 4's estimate is 60 percentage points below it; the whole stated range lies below it.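

In this assay, putting hydrogen in place of methoxy on an aromatic carbon gives a number 69 percentage points higher from compound 3 to compound 4 (beyond the scatter), a large loss of effect on this core. The same change does not carry over in size from one core to the other: the same change on two cores in this assay, a number 8 percentage points higher (within the scatter) from compound 1 to compound 2 and a number 69 percentage points higher (beyond the scatter) from compound 3 to compound 4, 61 percentage points apart, beyond the scatter of two such steps. This shows that, for these two pairs, a step seen on one core cannot be used to predict its size on the other, but it does not show which difference between the cores matters, and two pairs make no general rule.

The compounds shown leave open whether a hydroxyl group or a chlorine atom at this place would behave more like methoxy or like hydrogen. As far as these compounds go, each number also comes from a single concentration, so it speaks only of a stronger or weaker effect at that concentration, and how these compounds compare at other concentrations remains open.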